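Fluoroanilide ureas against rice: whole-organism activity notes

The source may hold more compounds than are shown below. What is called first, only, known or untested is meant among the compounds shown, and "the series" means these compounds.

Three urea compounds on a shared core have been measured in an ADME assay on the whole organism with Oryza sativa as the target, tested at 0.1 uM; a lower number here means a stronger effect, a higher number a weaker effect of the compound at the concentration tested. Compound 1 `C[C@@H](NC(=O)Nc1ccccc1F)c1ccccc1` gives 97% in this assay. Compound 2 `C[C@H](NC(=O)Nc1cccc(F)c1)c1ccccc1` gives 97% in this assay; compound 1 and compound 2 are level at the digits recorded, and the difference between the two cores is not broken down here. Compound 3 `C[C@H](NC(=O)Nc1cccc(F)c1F)c1ccccc1` gives 100% in this assay. The change from compound 2 to compound 3 is fluoro in place of hydrogen on an aromatic carbon and it brought a number 3 percentage points higher from compound 2 to compound 3 (within the scatter). Compound 4 `C[C@@H](NC(=O)Nc1c(F)cccc1F)c1ccccc1` awaits measurement. The change from compound 1 to compound 4 is fluoro in place of hydrogen on an aromatic carbon; here the entering fluoro is ortho to a large group and meta to a fluoro group, whereas from compound 2 to compound 3 it is ortho to a fluoro group and ortho to a large group, so this is the same kind of change, not the same change. Because compound 1 stands at 97% and the earlier step was a number 3 percentage points higher from compound 2 to compound 3 (within the scatter), compound 4 is expected to shift by a number 2 percentage points higher from compound 1 to compound 4 (within the scatter) in this assay. Compound 4 is estimated at 99% in this assay, likely between 94% and 100%.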

Compound 4, a percentage reported as activity, at one concentration (the size of the read-out at that concentration, not a potency): 100%
Beside the measured number, compound 4's estimate is 1 percentage points below it, within the range that was stated.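

In this assay, fluoro in place of hydrogen on an aromatic carbon gives a number 3 percentage points higher from compound 1 to compound 4 (within the scatter). Set beside the earlier step, the change reads alike on the two cores: the same change on two cores in this assay, a number 3 percentage points higher (within the scatter) from compound 2 to compound 3 and a number 3 percentage points higher (within the scatter) from compound 1 to compound 4, 0 percentage points apart, within the scatter of two such steps. This shows that the change carried from one core to the other without a difference beyond the scatter, but with both steps themselves within the scatter, it does not show that the entering fluoro has any effect of its own in this assay, and two steps, with the fluoro entering at different places, give no rule for other cores.

Open, going by these compounds, is whether a group other than fluoro on the same aromatic ring, such as chloro, methoxy or trifluoromethyl, would give a step beyond the scatter. Also open, on these data alone, is whether an amine or a carboxylic acid elsewhere on the shared core, or a longer chain in place of the methyl group, would shift the read-out.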